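Para-substituent change on the phenyl ring, cytotoxicity series

This account rests on a few compounds, and the source may have more. Where it says the series, first, only, none or still open, it means among the compounds named here.

Measured so far in a functional assay on U-87MG ATCC cells (Homo sapiens) for cytotoxicity, read by MTT assay, with a stated time of 48 h; on this read-out higher numbers stand for weaker inhibition and lower numbers for stronger inhibition:
compound 1 `Cc1ccc(-c2ccnc(Nc3ccc4c(c3)c(/C=C3/C(=O)Nc5ccccc53)cn4C)n2)cc1`: > 100000 nM
compound 2 `COc1ccc(-c2ccnc(Nc3ccc4c(c3)c(/C=C3/C(=O)Nc5ccccc53)cn4C)n2)cc1`: > 100000 nM
compound 3 `Cn1cc(/C=C2/C(=O)Nc3ccccc32)c2cc(Nc3nccc(-c4ccc(Cl)cc4)n3)ccc21`: 5820 nM

Compound 2 sits at the limit of this assay and its value is a limit, not a number. Compound 1 sits at the same limit, as noted in the limit of > 100000 nM in this assay, at which 2 of the 3 values shown sit. Compound 3 gives a number, and an at least 17-fold lower number from compound 2 to compound 3 (1.23 log units; beyond the scatter) and an at least 17-fold lower number from compound 1 to compound 3 (1.23 log units; beyond the scatter) are both large. Between the two limits, a step that the two limits leave unreadable from compound 1 to compound 2 cannot be read.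

Compound 4 `Cn1cc(/C=C2/C(=O)Nc3ccccc32)c2cc(Nc3nccc(-c4ccc(C(F)(F)F)cc4)n3)ccc21` is not yet measured. The change from compound 2 is trifluoromethyl in place of methoxy on an aromatic carbon. For the measured compounds named here, the only steps that bear on it are the two from a methyl or methoxy to chloro at the same place, both large and downward. Going by the values given here, no measured compound carries trifluoromethyl here, so the size of the step is uncertain, and a limit remains possible.

For compound 4 the expected step is an at least 5.0-fold lower number from compound 2 to compound 4 (0.69 log units; beyond the scatter), a lower number in this assay. The estimate for compound 4 is 20000 nM, within 3000 nM to 100000 nM.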

Compound 4, half-maximal inhibitory concentration: 26000 nM
Beside the measured number, compound 4's estimate is 1.3-fold (0.11 log units) below it; measured number inside the range.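

In this assay the move away from the limit is no longer confined to chloro, since trifluoromethyl also gives a number, with an at least 3.8-fold lower number from compound 2 to compound 4 (0.58 log units; beyond the scatter) and with an at least 3.8-fold lower number from compound 1 to compound 4 (0.58 log units; beyond the scatter) as well. For the compounds shown here, for the first time two groups at this place can be set against each other as numbers, and they are not interchangeable, with a 4.5-fold higher number from compound 3 to compound 4 (0.65 log units; beyond the scatter) so that chloro gives the lower number. Compound 1 and compound 2 still give only limits, not numbers, and the step between them cannot be read: the limit of > 100000 nM in this assay, at which 2 of the 4 values shown sit.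

As far as these compounds go, whether the gap between chloro and trifluoromethyl extends to fluoro, bromo or a nitrile at this place stays open. From the compounds shown here alone, how an amine or a carboxylic acid there would compare with compound 3 is also open.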